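The source may hold more compounds than are shown below. What is called first, only, known or untested is meant among the compounds shown, and "the series" means these compounds.

Measured in a functional assay on NCI-H460 cells (Homo sapiens) for inhibition, read by sulforhodamine B assay, with a stated time of 48 h; on this read-out lower numbers stand for stronger inhibition of growth and higher numbers for weaker inhibition of growth:
- compound 1 `CC(C)(C)NCc1c(C(=O)O)nn(-c2ccc(Cl)cc2)c1-c1ccc(F)cc1`: > 623000 nM
- compound 2 `CC(C)(C)NCc1c(C(=O)O)nn(-c2ccc(Cl)cc2)c1-c1ccc(Br)cc1`: > 542000 nM
- compound 3 `COc1ccc(-c2c(CNC(C)(C)C)c(C(=O)O)nn2-c2ccc(Cl)cc2)cc1`: > 605000 nM

Compound 3 stands at > 605000 nM, and this is a limit, not a number. The entries for compound 1 and compound 2 are limits as well, so no order can be read among the three compounds.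

Compound 4 `CC(C)(C)NCc1c(C(=O)O)nn(-c2ccc(Cl)cc2)c1-c1ccc([N+](=O)[O-])cc1` has nitro in place of methoxy on an aromatic carbon, the change from 4-methoxyphenyl to 4-nitrophenyl: nitro in place of methoxy on an aromatic carbon.

Among the measured compounds shown here, three measured steps bear on this change, each an exchange of one group on an aromatic carbon: a step that the two limits leave unreadable from compound 1 to compound 2, a step that the two limits leave unreadable from compound 1 to compound 3 and a step that the two limits leave unreadable from compound 2 to compound 3. None of them has a readable size, and none gives a direction. No step beyond the scatter is therefore expected in this assay, and no direction can be assigned. Compound 4 is expected to end at a limit too, an expectation that rests on compound 3, whose limit is > 605000 nM.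

The expected change is an at least 1.0-fold lower number from compound 3 to compound 4 (0.01 log units; that floor lies within the scatter). The estimate for compound 4 is 580000 nM. The expected range for compound 4 runs from 300000 nM to 700000 nM.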

Compound 4, concentration for 50% growth inhibition: 141000 nM
For compound 4 the middle estimate is 4.1-fold (0.61 log units) above the measured one; measured number below the stated range.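

In this assay, among the compounds shown here, compound 4 gives 141000 nM, the only value among the four compounds that is not a limit, so the position para to a large group can register a change in this assay. The change to nitro gives an at least 4.2-fold lower number from compound 3 to compound 4 (0.63 log units; beyond the scatter), and the same exchange against the other two groups gives an at least 3.8-fold lower number from compound 2 to compound 4 (0.58 log units; beyond the scatter) and an at least 4.4-fold lower number from compound 1 to compound 4 (0.64 log units; beyond the scatter), while the steps among compound 1, compound 2 and compound 3 cannot be read. All three new steps are floors and not sizes, and compound 3, the direct partner in the change from 4-methoxyphenyl to 4-nitrophenyl, is held at a limit and not a number: the limit of > 605000 nM in this assay, at which 1 of the 4 values shown sits.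

Whether this gain belongs to nitro alone stays open, as the readable value rests on the single compound 4, and nothing shown ties it to any property of that group. A nitrile or an amide at the same place would show whether a second group also leaves the limit, and how far the value of compound 4 can be matched.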